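The source may report more compounds than this note shows. Statements on the series, on what has been measured and on what is new or still open speak of the compounds shown alone.

In a functional assay on cells (leukaemia cell line, Homo sapiens) for inhibition, read by sulforhodamine B assay, with a stated time of 48 h (on this read-out lower numbers stand for stronger inhibition of growth and higher numbers for weaker inhibition of growth), compound 1 `O=S(=O)(Nc1cc(F)cc(F)c1)c1ccc(-c2cnc(C3CC3)o2)cc1` gives 80000 nM. Compound 2 `Cc1cc(Cl)ccc1NS(=O)(=O)c1ccc(-c2cnc(C3CC3)o2)cc1` gives 54700 nM, which places it level with compound 1 once the usual scatter is allowed for. For the measured compounds named here, the only measured step is a 1.5-fold lower number from compound 1 to compound 2 (0.17 log units; within the scatter), made by putting 4-chloro-2-methylphenyl in place of 3,5-difluorophenyl on a sulfonamide nitrogen. Compound 3 `O=S(=O)(Nc1ccc(I)c(Cl)c1)c1ccc(-c2cnc(C3CC3)o2)cc1` changes the group at that same place: 3-chloro-4-iodophenyl in place of 4-chloro-2-methylphenyl on a sulfonamide nitrogen. That one small step gives no direction, so no shift beyond the scatter is expected. The estimated step is a 1.2-fold lower number from compound 2 to compound 3 (0.08 log units; within the scatter). Compound 3 is expected at 45000 nM, with an estimated range of 15000 nM to 100000 nM.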

Compound 3, concentration for total growth inhibition: 19600 nM
Compound 3: the middle estimate sits 2.3-fold (0.36 log units) above what was measured, within the range that was stated.
By their numbers in this assay, from the lowest: compound 3; then compounds 2 and 1 (each within the scatter of the next).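

In this assay the group on the sulfonamide nitrogen can shift the number beyond the scatter, with a 2.8-fold lower number from compound 2 to compound 3 (0.45 log units; beyond the scatter) and a 4.1-fold lower number from compound 1 to compound 3 (0.61 log units; beyond the scatter) both modest, so compound 3 is the strongest of the three. The 4-chloro-2-methylphenyl and 3-chloro-4-iodophenyl groups have the same heavy-atom count, so that count does not separate them. Nothing measured here explains the shift.

Whether iodine drives the change remains open, since the only iodine-bearing compound shown also carries chlorine. As far as these compounds go, how an amine or a carboxylic acid on that phenyl ring would read is also open.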